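Compound 1 to compound 3: dimethylamino for amino

The compounds below may be only part of what the source reports. "The series", "measured", "known", "first", "only" and "open" are said of these compounds alone.

For the measured compounds named here, in a functional assay on KB cells (Homo sapiens) for inhibition, with a stated time of 72 h (a lower number here means a stronger inhibitor, a higher number a weaker inhibitor), compound 1 (`COc1ccc(S(=O)(=O)N2CCc3cccc(-c4ccc(N)cc4)c32)cc1`) gives 249 nM as the higher of the two numbers so far, and compound 2 (`COc1ccc(S(=O)(=O)N2CCc3cccc(-c4ccc(F)c(F)c4)c32)cc1`) gives 45 nM as the lower. Compound 3 (`COc1ccc(S(=O)(=O)N2CCc3cccc(-c4ccc(N(C)C)cc4)c32)cc1`) has dimethylamino in place of amino on an aromatic carbon. Going by the values given here, the only measured step bearing on this change is a 5.5-fold lower number from compound 1 to compound 2 (0.74 log units; beyond the scatter) for 3,4-difluorophenyl in place of 4-aminophenyl. It is a different replacement, so a smaller step in the same direction is expected. Compound 3 is estimated at 130 nM within a range of 45 nM to 380 nM as the expected value. This estimate means a 1.9-fold lower number from compound 1 to compound 3 (0.28 log units; within the scatter) as the expected step.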

Compound 3, half-maximal inhibitory concentration: 539 nM
Compound 3: middle estimate off by 4.1-fold (0.62 log units), on the low side, outside the stated range (above it).
By their numbers in this assay, from the lowest: compound 2; then compound 1; then compound 3.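

In this assay, dimethylamino in place of amino on the aromatic carbon raises the number rather than lowering it (a 2.2-fold higher number from compound 1 to compound 3 (0.34 log units; beyond the scatter)), so replacing the amino hydrogens with methyl groups brings no gain at this position. The replacement also widens the gap to the 3,4-difluorophenyl compound (a 12-fold higher number from compound 2 to compound 3 (1.08 log units; beyond the scatter)), leaving both nitrogen-bearing groups on the weaker side of it. Nothing measured here explains either step.

Still open, on these data alone, is how an acetamide, a carboxylic acid or a single fluorine would fare at this position. Also open, as far as these compounds go, is whether a monomethylamino group would fall between amino and dimethylamino.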